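Replacing 4-chlorobenzyl with 3-methylbenzyl on a shared core

The source may report more compounds than this note shows. Statements on the series, on what has been measured and on what is new or still open speak of the compounds shown alone.

In an ADME assay on L6 cells (Rattus norvegicus) for cytotoxicity, read by resazurin assay, with a stated time of 70 h (on this read-out higher numbers stand for weaker inhibition and lower numbers for stronger inhibition), compound 1 `CC(=O)Oc1ccc2c(c1)C(C)=CC(C)(C)N2Cc1ccc(Cl)cc1` gives 22000 nM and compound 2 `CC(=O)Oc1ccc2c(c1)C(C)=CC(C)(C)N2Cc1ccc(C(F)(F)F)cc1` gives 14000 nM with the two values within the scatter of each other. Going by the values given here, compound 1 thus stands level with the only other measured compound. Compound 3 `CC(=O)Oc1ccc2c(c1)C(C)=CC(C)(C)N2Cc1cccc(C)c1` has not yet been measured. Its difference from compound 1 is 3-methylphenyl in place of 4-chlorophenyl on a saturated chain carbon bound to a nitrogen on an aromatic ring in a ring with 3-methylphenyl in place of 4-chlorophenyl on a saturated chain carbon bound to a nitrogen on an aromatic ring in a ring. Among the compounds with values here, the one measured step, a 1.6-fold lower number from compound 1 to compound 2 (0.20 log units; within the scatter) with trifluoromethyl in place of chloro on an aromatic carbon, bears on this only indirectly, and no measured compound carries a 3-methylphenyl group. No step beyond the scatter is therefore expected in this assay and the estimated step is a 1.2-fold lower number from compound 1 to compound 3 (0.09 log units; within the scatter) for this change. Compound 3 is estimated at 18000 nM (expected range 8000 nM to 40000 nM).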

Compound 3, half-maximal inhibitory concentration: 28000 nM
Compound 3: middle estimate off by 1.6-fold (0.19 log units), on the low side; low and high end bracket the measured number.
By their numbers in this assay, from the lowest: compounds 2, 1 and 3 (each within the scatter of the next).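

In this assay, replacing 4-chlorophenyl with 3-methylphenyl on a saturated chain carbon bound to a nitrogen on an aromatic ring in a ring gives a 1.3-fold higher number from compound 1 to compound 3 (0.10 log units; within the scatter) and so stays within the scatter. The earlier step changed only the group on the aromatic carbon that carries chloro, whereas this change exchanges the whole 4-chlorophenyl group, and compound 3 shows that a 3-methylphenyl group at this position also gives no step beyond the scatter from compound 1. No available evidence bears on this result.

The compounds shown leave open how far 3-chlorophenyl or 4-methylphenyl would separate the exchange of chloro for methyl from the different placing of the group. As far as these compounds go, whether an amine or a carboxylic acid on the phenyl ring, or a longer chain in place of the benzyl group, would give a step beyond the scatter also remains open.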